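This account rests on a few compounds, and the source may have more. Where it says the series, first, only, none or still open, it means among the compounds named here.

Measured compounds:
compound 1 `CCOC(=O)c1sc2ccc(NCc3nc[nH]c3C)cc2c1NC(=O)c1ccc(C)cc1`, 11400 nM
compound 2 `CCOC(=O)c1sc2ccc(NCc3nc[nH]c3C)cc2c1NC(=O)c1ccc(C(F)(F)F)cc1`, 12800 nM
compound 3 `CCOC(=O)c1sc2ccc(NCc3nc[nH]c3C)cc2c1NC(=O)c1ccc(F)c(Cl)c1`, 2910 nM

In a functional assay on HeLa cells (Homo sapiens) for antiproliferative activity, read by MTT assay, with a stated time of 48 h (on this read-out lower numbers stand for stronger inhibition of growth and higher numbers for weaker inhibition of growth), compound 2 gives the highest of the three numbers; compound 1 sits nearest, a 1.1-fold higher number from compound 1 to compound 2 (0.05 log units; within the scatter), and compound 3 furthest, a 4.4-fold lower number from compound 2 to compound 3 (0.64 log units; beyond the scatter). Compound 4 `CCOC(=O)c1sc2ccc(N)cc2c1NC(=O)c1ccc(C(F)(F)F)cc1` differs from compound 2 by hydrogen in place of (5-methyl-1H-imidazol-4-yl)methyl on a nitrogen on an aromatic ring. None of the three measured steps bears on this change: a 3.9-fold lower number from compound 1 to compound 3 (0.59 log units; beyond the scatter) and the others all alter the aryl group on the carbonyl carbon while the amine substituent is kept. The data therefore give no guide to direction, and the step of a 1.2-fold higher number from compound 2 to compound 4 (0.07 log units; within the scatter) is expected to stay roughly within the scatter, with wide uncertainty. For compound 4 the estimate in this assay is 15000 nM, ranging from 4000 nM to 60000 nM.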

Compound 4, concentration for 50% growth inhibition: 6680 nM
Compound 4: the middle estimate sits 2.2-fold (0.35 log units) above what was measured, and the stated range covers the measured number.
By their numbers in this assay, from the lowest: compound 3; then compounds 4, 1 and 2 (each within the scatter of the next).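

In this assay, the amine substituent changes for the first time among these compounds, and hydrogen in place of (5-methyl-1H-imidazol-4-yl)methyl gives a 1.9-fold lower number from compound 2 to compound 4 (0.28 log units; within the scatter). With the 4-(trifluoromethyl)phenyl amide, this position therefore tolerates loss of the whole group without a change beyond the scatter. Nothing measured here offers an explanation for this result. From the compounds shown here alone, it remains open whether the plain amino group behaves the same way with the 3-chloro-4-fluorophenyl amide of compound 3. Other substituents on this nitrogen, such as methyl, acetyl or benzyl, also remain open.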